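A few compounds are considered here, and "the series" means these few. Any claim that something is new, unique, unknown or untested is made for them only; others in the source may bear on it.

Measured compounds:
- compound 1 `O=C1NC(=S)S/C1=C\c1cc2cc(Cl)ccc2nc1Cl` — > 100 ug/mL
- compound 2 `COc1ccc2cc(/C=C3\SC(=S)NC3=O)c(Cl)nc2c1` — > 100 ug/mL

In a toxicity assay on PANC-1 cells (Homo sapiens) for cytotoxicity, read by MTT assay, with a stated time of 48 h (on this read-out higher numbers stand for weaker inhibition of growth and lower numbers for stronger inhibition of growth), compound 1 gives > 100 ug/mL, which is a limit of the assay rather than a number. Compound 2 gives > 100 ug/mL in this assay, again a limit. Compound 1 therefore stands at the limit of > 100 ug/mL in this assay, at which 2 of the 2 values shown sit, and nothing ranks it against compound 2 on these numbers; both are simply unresolved at the top of the tested range.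

Compound 3 `O=C1NC(=S)S/C1=C\c1cc2cc(F)ccc2nc1Cl` differs from compound 1 by one change: fluoro in place of chloro on an aromatic carbon. Going by the values given here, no step between two measured compounds is available for this change, so its size cannot be read from the series. With both measured values sitting at the same limit, the expectation in this assay is for no step beyond the usual scatter.

Compound 3 is accordingly expected at 150 ug/mL, between 50 ug/mL and 400 ug/mL, most probably reported again as a limit. The step is estimated as a step that the limit leaves unreadable from compound 1 to compound 3.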

Compound 3, concentration for 50% growth inhibition: > 100 ug/mL
Compound 3 ended at the assay's limit; the forecaster's own chance of this, stated with the estimate: 85%; the middle value is on the limit's open side.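

In this assay compound 3, like compound 1, stands at a limit and not a number, so no step can be read for fluoro in place of chloro on an aromatic carbon: the limit of > 100 ug/mL in this assay, at which 3 of the 3 values shown sit. The compounds shown leave open whether any change on the shared core gives a readable value for growth inhibition.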